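From 1H-indol-6-yl to 4-vinylphenyl on a shared core

A few compounds are considered here, and "the series" means these few. Any claim that something is new, unique, unknown or untested is made for them only; others in the source may bear on it.

In a functional assay on MCF7 cells (Homo sapiens) for inhibition, read by CCK-8 assay, with a stated time of 48 h (a lower number here means a stronger inhibitor, a higher number a weaker inhibitor), compound 1 `COc1cc(-c2ccnc3cc(-c4ccc(C)c(C)c4)nn23)cc(OC)c1OC` gives 26 nM and compound 2 `COc1cc(-c2ccnc3cc(-c4ccc5cc[nH]c5c4)nn23)cc(OC)c1OC` gives 23 nM. These two numbers lie within the scatter of each other, so compound 2 stands level with compound 1. Compound 3 `C=Cc1ccc(-c2cc3nccc(-c4cc(OC)c(OC)c(OC)c4)n3n2)cc1` differs from compound 2 in one place: 4-vinylphenyl in place of 1H-indol-6-yl on an aromatic carbon. Among the compounds with values here, one measured step bears on this: a 1.1-fold lower number from compound 1 to compound 2 (0.05 log units; within the scatter), with 1H-indol-6-yl in place of 3,4-dimethylphenyl on the same aromatic carbon, and it stays within the scatter. No step beyond the scatter is therefore expected in this assay. The expected change is a 1.3-fold higher number from compound 2 to compound 3 (0.12 log units; within the scatter). For compound 3 the estimated value is 30 nM, with an expected range from 12 nM to 80 nM.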

Compound 3, half-maximal inhibitory concentration: 193 nM
Beside the measured number, compound 3's estimate is 6.4-fold (0.81 log units) below it; the whole stated range lies below it.
By their numbers in this assay, from the lowest: compounds 2 and 1 (each within the scatter of the next); then compound 3.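

Until now this aromatic carbon, next to the ring nitrogen, seemed to tolerate a change of group, but 4-vinylphenyl gives an 8.4-fold higher number from compound 2 to compound 3 (0.92 log units; beyond the scatter) and a 7.4-fold higher number from compound 1 to compound 3 (0.87 log units; beyond the scatter). So the position does respond to what it carries: 1H-indol-6-yl and 3,4-dimethylphenyl stand level, while 4-vinylphenyl falls clearly behind both. Nothing available explains this loss. Still open, going by these compounds, is whether the double bond outside the aromatic ring matters or the single para-free shape of the group does not: 4-ethylphenyl, or a phenyl ring carrying an amine, would help separate these.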